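Anilino variation on the shared core: compound 3 to compound 4

The source may report more compounds than this note shows. Statements on the series, on what has been measured and on what is new or still open speak of the compounds shown alone.

Three compounds of the series have numbers in a functional assay on MOLT-4 cells (Homo sapiens) for antiproliferative activity, read by CCK-8 assay, with a stated time of 72 h; on this read-out lower numbers stand for stronger inhibition and higher numbers for weaker inhibition. Compound 1 `Cc1cc(Nc2cc(N3CCN(C)CC3)nc(Nc3cccc(Cl)c3)n2)n[nH]1` gives 20.1 nM. Compound 2 `Cc1cc(Nc2cc(N3CCN(C)CC3)nc(Nc3ccc(Cl)cc3)n2)n[nH]1` gives 53.1 nM in this assay. Compound 3 `Cc1cc(Nc2cc(N3CCN(C)CC3)nc(Nc3cccc([N+](=O)[O-])c3)n2)n[nH]1` gives 26 nM in this assay; this is the second highest of the three numbers, close to compound 1 and separated from compound 2 by a step beyond the scatter. The steps among them read as follows: a 2.6-fold higher number from compound 1 to compound 2 (0.42 log units; beyond the scatter); a 1.3-fold higher number from compound 1 to compound 3 (0.11 log units; within the scatter); a 2.0-fold lower number from compound 2 to compound 3 (0.31 log units; beyond the scatter).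

Compound 4 `COc1ccc(Nc2nc(Nc3cc(C)[nH]n3)cc(N3CCN(C)CC3)n2)cc1` has not yet been measured. Its difference from compound 3: 4-methoxyphenyl in place of 3-nitrophenyl on a nitrogen on an aromatic ring. Going by the values given here, two measured steps bear on this. The only earlier move of a substituent from the 3-position of the phenyl to the 4-position, a 2.6-fold higher number from compound 1 to compound 2 (0.42 log units; beyond the scatter), raised the number, and the return to a 3-substituted phenyl, a 2.0-fold lower number from compound 2 to compound 3 (0.31 log units; beyond the scatter), lowered it again. Methoxy itself has no precedent in the series, so the size of its own contribution is open. On balance a modest step toward a higher number in this assay is expected for compound 4, a 2.3-fold higher number from compound 3 to compound 4 (0.36 log units; beyond the scatter). Compound 4 is therefore estimated at 60 nM, with a range from 25 nM to 150 nM.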

Compound 4, half-maximal inhibitory concentration: 116 nM
For compound 4 the middle estimate is 1.9-fold (0.29 log units) below the measured one; low and high end bracket the measured number.
By their numbers in this assay, from the lowest: compounds 1 and 3 (each within the scatter of the next); then compound 2; then compound 4.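

Methoxy in place of chloro gives a 2.2-fold higher number from compound 2 to compound 4 (0.34 log units; beyond the scatter) in this assay and shows that, with the group held on the 4-position of the phenyl, its identity moves the number; the earlier compounds showed only that 3-chlorophenyl and 4-chlorophenyl differ and that nitro and chloro on the 3-substituted phenyl stay within the scatter. The wider steps, a 4.5-fold higher number from compound 3 to compound 4 (0.65 log units; beyond the scatter) and a 5.8-fold higher number from compound 1 to compound 4 (0.76 log units; beyond the scatter) in the same assay, change the group and its place together, and they leave 4-methoxyphenyl with the highest number of the four compounds, so the 4-chlorophenyl of compound 2 is no longer the upper end of the series. No measurement at hand gives a reason for any of these steps.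

From the compounds shown here alone, whether a 3-methoxyphenyl would sit with compounds 1 and 3 or stay near compound 4 remains open, so for methoxy the share of the place and the share of the group cannot be separated. Also open, going by these compounds, are 4-nitrophenyl, which would complete the same comparison for nitro, and how an amine or a carboxylic acid on the phenyl would read.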